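Hydrazone aryl variation on a shared urea core

The compounds below may be only part of what the source reports. "The series", "measured", "known", "first", "only" and "open" are said of these compounds alone.

Measured so far in a functional assay on HT-29 cells (Homo sapiens) for cytotoxicity, read by MTT assay, with a stated time of 72 h; a lower number here means a stronger inhibitor, a higher number a weaker inhibitor:
compound 1 `CN(C)CCn1cnnc1-c1cc(Oc2ccc(NC(=O)N/N=C/c3c(O)ccc4ccccc34)cc2F)ccn1` gives 670 nM
compound 2 `COc1ccc(/C=N/NC(=O)Nc2ccc(Oc3ccnc(-c4nncn4CCN(C)C)c3)c(F)c2)c(OC)c1` gives 1780 nM
compound 3 `COc1ccc(/C=N/NC(=O)Nc2ccc(Oc3ccnc(-c4nncn4CCN(C)C)c3)c(F)c2)cc1O` gives 960 nM

Compound 3 stands second highest of the three numbers; the step of a 1.4-fold higher number from compound 1 to compound 3 (0.16 log units; within the scatter) and the step of a 1.9-fold lower number from compound 2 to compound 3 (0.27 log units; within the scatter) both lie within the scatter, so no order among these three is claimed. Within the data shown here, only the step of a 2.7-fold higher number from compound 1 to compound 2 (0.42 log units; beyond the scatter) is beyond the scatter.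

Compound 4 `CN(C)CCn1cnnc1-c1cc(Oc2ccc(NC(=O)N/N=C/c3c(Cl)cccc3Cl)cc2F)ccn1` changes the aryl group of the hydrazone: 2,6-dichlorophenyl in place of 3-hydroxy-4-methoxyphenyl on a carbon with a double bond to nitrogen. Among the measured compounds shown here, no measured step swaps in a group of this kind, so the measured steps bear on it only loosely, and all are modest. The estimate for compound 4 in this assay is 1200 nM (range 500 nM to 3000 nM), a step of a 1.3-fold higher number from compound 3 to compound 4 (0.10 log units; within the scatter) expected to stay near the scatter.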

Compound 4, half-maximal inhibitory concentration: 280 nM
For compound 4 the middle estimate is 4.3-fold (0.63 log units) above the measured one; the measured number lies below the stated range.
By their numbers in this assay, from the lowest: compound 4; then compounds 1, 3 and 2 (each within the scatter of the next, the first and the last beyond it).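

In this assay the aryl group on a carbon with a double bond to nitrogen need not carry oxygen: 2,6-dichlorophenyl gives a 3.4-fold lower number from compound 3 to compound 4 (0.54 log units; beyond the scatter), and likewise a 6.4-fold lower number from compound 2 to compound 4 (0.80 log units; beyond the scatter). It also outperforms the larger 2-hydroxynaphthalen-1-yl group, with a 2.4-fold lower number from compound 1 to compound 4 (0.38 log units; beyond the scatter), making compound 4 the strongest of the four. Nothing available explains this gain.

Going by these compounds, whether one chlorine alone would hold the lower number remains open. So does the effect of methyl groups or an amine in place of the chlorines.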